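The source may report more compounds than this note shows. Statements on the series, on what has been measured and on what is new or still open speak of the compounds shown alone.

Measured so far:
compound 1, `CCCNc1cccc(NC(=O)c2ccc(OCCC)cc2)n1`: 15400 nM
compound 2, `CCCCCCNc1cccc(NC(=O)c2ccc(OCCC)cc2)n1`: only a limit reported

In an in vitro assay on HEK-tsA201 cells for antagonist activity at Neuronal acetylcholine receptor; alpha4/beta2 (Homo sapiens), read by fluorescence and calcium flux (a higher number here means a weaker inhibitor, a lower number a stronger inhibitor), compound 1 gives 15400 nM. For compound 2 the assay reports only a limit, > 100000 nM. Compound 2 thus sits at the limit of > 100000 nM in this assay, at which 1 of the 2 values shown sits, the weakest position among the numbers shown. Going by the values given here, the single measured step, an at least 6.4-fold higher number from compound 1 to compound 2 (0.81 log units; beyond the scatter), takes propyl to hexyl on the nitrogen on an aromatic ring and weakens inhibition.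

Compound 3, `CCCOc1ccc(C(=O)Nc2cccc(Nc3ccc(OC)cc3)n2)cc1`, differs from compound 2 in that (4-methoxyphenyl in place of hexyl on a nitrogen on an aromatic ring). The hexyl chain leaves entirely and an aromatic group enters. The measured step bears on this only indirectly: a longer chain from compound 1 to compound 2 cost potency, so removing the hexyl could recover some of it, but neither measured compound shows whether a 4-methoxyphenyl is tolerated on that nitrogen. Compound 3 is expected at 30000 nM, with a range of 8000 nM to 100000 nM. That estimate means an at least 3.3-fold lower number from compound 2 to compound 3 (0.52 log units; beyond the scatter), taken against the limit of compound 2.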

Compound 3, half-maximal inhibitory concentration: > 100000 nM
Compound 3 was reported as a limit; the forecaster's own chance of this, stated with the estimate: 40%; middle value at least 3.3-fold (0.52 log units) away from the limit.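

In this assay exchanging the propyl on the nitrogen for a 4-methoxyphenyl gives an at least 6.4-fold higher number from compound 1 to compound 3 (0.81 log units; beyond the scatter) and shows that the loss at this position is not confined to a longer saturated chain such as hexyl. Compound 3 is reported only as a limit, > 100000 nM, and is not a number. The step between the hexyl and 4-methoxyphenyl compounds cannot be read, so the two groups cannot be ranked, and both compounds rest at the same limit: the limit of > 100000 nM in this assay, at which 2 of the 3 values shown sit.

Open, as far as these compounds go, is whether an unsubstituted phenyl, a benzyl or a shorter ethyl chain on that nitrogen would give a measurable value. Also open, from the compounds shown here alone, is whether any group there, an amine-bearing chain included, would improve on the propyl of compound 1.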